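The source may hold more compounds than are shown below. What is called first, only, known or untested is meant among the compounds shown, and "the series" means these compounds.

Measured so far in a functional assay on SK-OV-3 cells (Homo sapiens) for cytotoxicity, read by MTT assay, with a stated time of 48 h; on this read-out lower numbers stand for stronger inhibition and higher numbers for weaker inhibition:
compound 1, `O=C(/C=C/c1ccc2c(c1)B(O)OC2)c1ccccc1`, gives 3400 nM
compound 2, `O=C(/C=C/c1ccc2c(c1)B(O)OC2)c1ccc(F)cc1`, gives 1400 nM
compound 3, `Cc1ccc(C(=O)/C=C/c2ccc3c(c2)B(O)OC3)cc1`, gives 3700 nM

Among these three, compound 3 has the highest number in this assay. Its gap to compound 1 is small: a 1.1-fold higher number from compound 1 to compound 3 (0.04 log units; within the scatter). Its gap to compound 2 is larger: a 2.6-fold higher number from compound 2 to compound 3 (0.42 log units; beyond the scatter).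

The next compound, compound 4, `CCc1ccc(C(=O)/C=C/c2ccc3c(c2)B(O)OC3)cc1`, differs from compound 3 in one place: methyl in place of hydrogen on a saturated chain carbon bound to an aromatic carbon. Seen one bond further out, the methyl group on the aromatic ring of compound 3 becomes an ethyl group.

Among the measured compounds shown here, only one measured step bears on this kind of change, the growth of that same substituent from hydrogen to methyl, and it stayed within the scatter: a 1.1-fold higher number from compound 1 to compound 3 (0.04 log units; within the scatter). The other step on the shared core, fluoro in place of hydrogen, a 2.4-fold lower number from compound 1 to compound 2 (0.39 log units; beyond the scatter), concerns a different group and gives no direct guide to lengthening a carbon chain. With one lengthening already leaving the number essentially unchanged, a further lengthening is expected to give no step beyond the scatter, a 1.1-fold lower number from compound 3 to compound 4 (0.02 log units; within the scatter). Compound 4 is therefore estimated at 3500 nM, with a range from 1500 nM to 8000 nM.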

Compound 4, half-maximal inhibitory concentration: 4400 nM
Estimate against measurement, compound 4: 1.3-fold (0.10 log units) below; low and high end bracket the measured number.
By their numbers in this assay, from the lowest: compound 2; then compounds 1, 3 and 4 (each within the scatter of the next).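

In this assay, growing the substituent from methyl to ethyl gives a 1.2-fold higher number from compound 3 to compound 4 (0.08 log units; within the scatter), so this further lengthening of the chain, like the earlier step from hydrogen to methyl, leaves the number level. Measured directly against the compound with only hydrogen at this place, the ethyl group also stays level, with a 1.3-fold higher number from compound 1 to compound 4 (0.11 log units; within the scatter), so hydrogen, methyl and ethyl cannot be told apart on this read-out. Compound 2 remains separate from this group, as the fluoro-to-ethyl comparison shows with a 3.1-fold higher number from compound 2 to compound 4 (0.50 log units; beyond the scatter), and nothing given here offers an explanation for either the flat run or the separate fluoro result.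

The compounds shown leave open whether a longer chain such as propyl, or a branched group such as isopropyl, would keep the number level at this place on the ring. They also leave open whether the lower number seen with fluoro would carry over to chloro, or whether a different kind of group, such as an amine or a methoxy group, would move the number in either direction.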